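Clearance in liver microsomes: methoxyphenyl for fluorophenyl

The source may hold more compounds than are shown below. What is called first, only, known or untested is meant among the compounds shown, and "the series" means these compounds.

Measured compounds:
compound 1 `COc1ccc(-c2c(S(=O)(=O)c3cc(Cl)cc(Cl)c3)cnc3c(F)cccc23)cc1`, 2.11 mL/min
compound 2 `O=S(=O)(c1ccc(F)c(F)c1)c1cnc2c(F)cccc2c1-c1cccc(F)c1`, 1.28 mL/min

In an ADME assay on microsomes from liver (Homo sapiens) for metabolic stability, tested at 2.5 uM (a higher number here means faster removal of the compound, a lower number slower removal), compound 2 gives 1.28 mL/min, the lowest of the two numbers. Its nearest neighbour is compound 1, which in this assay gives 2.11 mL/min, a difference that lies within the scatter, so the two cannot be told apart.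

Compound 3 `COc1ccc(-c2c(S(=O)(=O)c3ccc(F)c(F)c3)cnc3c(F)cccc23)cc1` is not yet measured. It differs from compound 2 in one place: 4-methoxyphenyl in place of 3-fluorophenyl on an aromatic carbon.

For the measured compounds named here, no step between measured compounds isolates this change. Compound 1 already carries the 4-methoxyphenyl group and gives 2.11 mL/min in this assay, so compound 3 is expected to land near it, with a step of a 1.3-fold higher number from compound 2 to compound 3 (0.12 log units; within the scatter) from compound 2 that is modest and upward, though not beyond the scatter. Compound 3 is therefore estimated at 1.7 mL/min, within a range from 0.9 mL/min to 3.2 mL/min.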

Compound 3, intrinsic clearance in a liver preparation (reported as CLH), per the amount of preparation that the assay uses: 2.12 mL/min
Compound 3: the middle estimate sits 1.2-fold (0.10 log units) below what was measured; the measured number falls inside the stated range.
By their numbers in this assay, from the lowest: compounds 2, 1 and 3 (each within the scatter of the next).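

In this assay, the exchange of 3-fluorophenyl for 4-methoxyphenyl on this aromatic carbon now has a direct reading (a 1.7-fold higher number from compound 2 to compound 3 (0.22 log units; within the scatter)), so this change at this position cannot be told from no change at all. Compound 3 also links the series on the sulfonyl sulfur, where 3,4-difluorophenyl stands in place of 3,5-dichlorophenyl (a 1.0-fold higher number from compound 1 to compound 3 (0.00 log units; within the scatter)), and that exchange likewise cannot be told from no change.

Going by these compounds, each exchange has been read only once, against a single partner, so it remains open whether either would behave the same with the other group held differently. Also open, on these data alone, is whether an amine or a carboxylic acid at this position would give a step beyond the scatter. No measurement shown here offers any explanation of these numbers.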